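Lengthening the chain from propyl to pentyl

The source may hold more compounds than are shown below. What is called first, only, known or untested is meant among the compounds shown, and "the series" means these compounds.

In a functional assay on cells (T-cell line, Homo sapiens) for inhibition (on this read-out lower numbers stand for stronger inhibition and higher numbers for weaker inhibition), compound 1 (`CCN1CCC(COC(c2ccccc2)c2ccccc2)CC1`) shows > 20000 nM, which is a limit of the assay and not a number. Within the data shown here, compound 2 (`CCCN1CCC(COC(c2ccccc2)c2ccccc2)CC1`) gives 17800 nM, the only true number so far. Compound 3 (`CCCCCN1CCC(COC(c2ccccc2)c2ccccc2)CC1`) carries ethyl in place of hydrogen on a saturated chain carbon, three bonds along the chain from an amine nitrogen in a ring, which turns propyl to pentyl. Among the measured compounds shown here, the only measured step that bears on this is an at least 1.1-fold lower number from compound 1 to compound 2 (0.05 log units; that floor lies within the scatter), a weak guide that favours, if anything, a modest fall in the number in this assay. The expected change is a 2.5-fold lower number from compound 2 to compound 3 (0.41 log units; beyond the scatter). Compound 3 is estimated at 7000 nM, with an expected range from 2000 nM to 20000 nM.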

Compound 3, half-maximal inhibitory concentration: 10800 nM
Estimate against measurement, compound 3: 1.5-fold (0.19 log units) below; measured number inside the range.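

In this assay, among these compounds, the ethyl at this place, which turns propyl to pentyl, gives a 1.6-fold lower number from compound 2 to compound 3 (0.22 log units; within the scatter) and so offers the first comparison between two true numbers, though not one that stands clear of the scatter. Across the whole series the chain change gives an at least 1.8-fold lower number from compound 1 to compound 3 (0.26 log units; that floor lies within the scatter) as a floor only, since the value of compound 1 is a limit and not a number: the limit of > 20000 nM in this assay, at which 1 of the 3 values shown sits.

The compounds shown leave open whether a longer chain such as heptyl would move the number beyond the scatter. They also leave open what a hydroxyl or a phenyl at the chain end would do.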